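The source may hold more compounds than are shown below. What is called first, only, known or untested is meant among the compounds shown, and "the series" means these compounds.

Three compounds on a shared core, compound 1 `CCCCC(OC)c1cccc(NC(=O)NCCCCl)c1`, compound 2 `CCCCC(OC)c1cccc(NC(=O)NC(=O)CCl)c1` and compound 3 `CCCCC(OC)c1cccc(NC(=O)NC(=O)CC)c1`, were tested in a functional assay on M21 cells (Homo sapiens) for antiproliferative activity, with a stated time of 48 h; on this read-out lower numbers stand for stronger inhibition and higher numbers for weaker inhibition. Compound 1 gives 51000 nM and compound 2 gives 4200 nM. For compound 3 the result is a limit of the assay, > 100000 nM, which is the limit of > 100000 nM in this assay, at which 1 of the 3 values shown sits. Exchanging chloro for methyl produced an at least 23-fold higher number from compound 2 to compound 3 (1.37 log units; beyond the scatter), while the reverse kind of change gave a 12-fold lower number from compound 1 to compound 2 (1.08 log units; beyond the scatter). Compound 4 `CCCCC(OC)c1cccc(NC(=O)CCl)c1` differs from compound 3 by chloromethyl in place of propanoylamino on a carbonyl carbon, so the chloromethyl carbonyl unit shared with compound 2 returns. A downward step is therefore expected, estimated as an at least 12-fold lower number from compound 3 to compound 4 (1.09 log units; beyond the scatter). Compound 4 is expected to give 8000 nM, with a likely range from 1500 nM to 50000 nM.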

Compound 4, half-maximal inhibitory concentration: 6900 nM
Compound 4: middle estimate off by 1.2-fold (0.06 log units), on the high side; low and high end bracket the measured number.
By their numbers in this assay, from the lowest: compounds 2 and 4 (each within the scatter of the next); then compound 1. At a limit, above all of these: compound 3.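

With a 1.6-fold higher number from compound 2 to compound 4 (0.22 log units; within the scatter) as the step, chloromethyl alone on the carbonyl carbon serves as well as the longer ((chloromethyl)carbonyl)amino group. The same short group also stands well apart from the other two partners, with a 7.4-fold lower number from compound 1 to compound 4 (0.87 log units; beyond the scatter) and an at least 14-fold lower number from compound 3 to compound 4 (1.16 log units; beyond the scatter) as the steps. Compound 3 is a limit of the assay, so its step is only a floor: the limit of > 100000 nM in this assay, at which 1 of the 4 values shown sits.

A bromomethyl group or a longer chain on this carbonyl carbon could show whether the chlorine itself matters. The compounds shown leave that open.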